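The compounds below may be only part of what the source reports. "The series", "measured", "known", "first", "only" and "open" are said of these compounds alone.

Measured in an ADME assay on MDCK cells (Canis lupus familiaris) for cytotoxicity; a lower number here means that less compound is tolerated, a higher number that more compound is tolerated:

- Compound 1 `O=[N+]([O-])C1=NNc2ncnn2C1c1ccc(O)c(O)c1`: > 1630000 nM
- Compound 2 `O=[N+]([O-])C1=NNc2nc(C(F)(F)F)nn2C1c1ccc(O)c(O)c1`: 183000 nM
- Compound 3 `O=[N+]([O-])C1=NNc2nc(C(F)(F)F)nn2C1c1ccc(O)c(O)c1O`: 67000 nM

Compound 1 gives > 1630000 nM, which is a limit of the assay and not a number. Of the two true numbers, compound 2 stands higher at 183000 nM, and compound 3 gives 67000 nM.

Compound 4 `O=[N+]([O-])C1=NNc2nc(C(F)(F)F)nn2C1O` has not yet been measured. Its difference from compound 2 is hydroxy in place of 3,4-dihydroxyphenyl on a saturated ring carbon. Among the compounds with values here, no measured step makes this exchange, so the evidence is indirect. Adding hydroxy on an aromatic carbon gave a 2.7-fold lower number from compound 2 to compound 3 (0.44 log units; beyond the scatter), which suggests that losing the ring and its hydroxy groups may raise the number. Compound 4 keeps the trifluoromethyl, whose introduction gave an at least 8.9-fold lower number from compound 1 to compound 2 (0.94 log units; beyond the scatter), so a return to the limit seen for compound 1 is not assumed. In this assay, a modest rise is expected, though with wide uncertainty. The expected change is a 2.2-fold higher number from compound 2 to compound 4 (0.34 log units; beyond the scatter). For compound 4 the estimated value is 400000 nM, with an expected range from 100000 nM to 1600000 nM.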

Compound 4, half-maximal cytotoxic concentration: 40000 nM
Estimate against measurement, compound 4: 10-fold (1.00 log units) above, outside the stated range (below it).
By their numbers in this assay, from the lowest: compounds 4 and 3 (each within the scatter of the next); then compound 2. At a limit, above all of these: compound 1.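

In this assay, within the data shown here, the earlier steps changed only aromatic carbons, whereas here the change falls on the saturated ring carbon, and hydroxy in place of 3,4-dihydroxyphenyl gives a 4.6-fold lower number from compound 2 to compound 4 (0.66 log units; beyond the scatter). The whole 3,4-dihydroxyphenyl can therefore leave this position without the number going up, so in this pair a low number does not depend on that aromatic ring. Nothing measured here explains why the number falls with this exchange.

Among these compounds, the single step cannot separate the loss of the 3,4-dihydroxyphenyl from the arrival of the hydroxy, so a plain hydrogen, a methoxy group, an amine or a short alkyl chain on this carbon would each be informative. Also open is how far the trifluoromethyl contributes to the number of compound 4, since no partner without that group is shown.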